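This account rests on a few compounds, and the source may have more. Where it says the series, first, only, none or still open, it means among the compounds named here.

In a physicochemical assay for lipophilicity, using the shake flask method, in phosphate buffer, measured as octanol-water partition, with a stated time of 2 h, at pH 7.4, tested at 1 uM (on this read-out lower numbers stand for lower lipophilicity and higher numbers for higher lipophilicity), compound 1 (`OC[C@H]1O[C@H](Oc2ccc(-n3ccc4ccccc43)cc2Cl)[C@@H](O)[C@@H](O)[C@@H]1O`) gives 1.8 and compound 2 (`O=[N+]([O-])c1ccc2c(ccn2-c2ccc(O[C@H]3O[C@H](CO)[C@@H](O)[C@H](O)[C@@H]3O)c(Cl)c2)c1`) gives 1.8 while compound 3 (`OC[C@H]1O[C@H](Oc2ccc(-n3ccc4ccccc43)cc2F)[C@@H](O)[C@@H](O)[C@@H]1O`) gives 2.4 as the highest of the three numbers, beyond the scatter from both others. Compound 4 (`O=[N+]([O-])c1ccc2c(ccn2-c2ccc(O[C@H]3O[C@H](CO)[C@@H](O)[C@H](O)[C@@H]3O)c(F)c2)c1`) differs from compound 3 by nitro in place of hydrogen (nitro in place of hydrogen on an aromatic carbon) on an aromatic carbon of a six-membered aromatic ring of carbon only, part of a fused or bridged system of two rings.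

The same exchange has been measured once, in the chloro pair, where no change at the digits printed from compound 1 to compound 2 (within the scatter) is the result. Among the measured compounds shown here, the other measured step, a number 0.60 log units higher from compound 1 to compound 3 (beyond the scatter) with fluoro in place of chloro, is a different change and shows only that the fluoro compound starts from a higher number. For the measured compounds named here, no measured pair tests the nitro exchange in the fluoro setting, so this rests on a single precedent.

The step expected in this assay is no change at the digits printed from compound 3 to compound 4 (within the scatter) and thus none beyond the scatter. Compound 4 is estimated at 2.4 with 1.9 to 2.8 as the expected range.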

Compound 4, distribution coefficient: 1.9
Compound 4: middle estimate off by 0.50 log units, on the high side; the measured number falls inside the stated range.
By their numbers in this assay, from the lowest: compounds 1, 2 and 4 (each within the scatter of the next); then compound 3.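

In this assay the nitro exchange at this position now gives a number 0.50 log units lower from compound 3 to compound 4 (beyond the scatter) while the chloro pair shows no change at the digits printed from compound 1 to compound 2 (within the scatter) so its outcome depends on which halogen the compound carries. Read the other way, fluoro in place of chloro gives a number 0.10 log units higher from compound 2 to compound 4 (within the scatter) among the nitro compounds against a number 0.60 log units higher from compound 1 to compound 3 (beyond the scatter) among those with hydrogen at this position, so the two exchanges do not add up across these four compounds. No measured evidence accounts for this dependence on the setting.

With nitro the only group other than hydrogen shown at this position, it remains open whether an amine or a carboxylic acid there would also give a step that differs between the fluoro and chloro settings. From the compounds shown here alone, whether bromo in place of either halogen would follow the fluoro or the chloro pair is equally open.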